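This account rests on a few compounds, and the source may have more. Where it says the series, first, only, none or still open, it means among the compounds named here.

Measured in a functional assay on SMMC-7721 cells (Homo sapiens) for cytotoxicity, read by MTT assay, with a stated time of 24 h; on this read-out higher numbers stand for weaker inhibition and lower numbers for stronger inhibition:
- compound 1 `O=C1/C(=C/c2cccnc2)CN(S(=O)(=O)c2ccc(Br)cc2)C/C1=C\c1ccccc1F`: 9100 nM
- compound 2 `Cc1ccc(S(=O)(=O)N2C/C(=C\c3cccnc3)C(=O)/C(=C/c3ccccc3C(F)(F)F)C2)cc1`: 6700 nM
- compound 3 `O=C1/C(=C/c2cccnc2)CN(S(=O)(=O)c2ccc([N+](=O)[O-])cc2)C/C1=C\c1ccccc1C(F)(F)F`: 15900 nM

Among the measured compounds shown here, the value of compound 3 lies within the scatter of that of compound 1 but stands clearly apart from that of compound 2, as the one direct comparison shows: a 2.4-fold higher number from compound 2 to compound 3 (0.38 log units; beyond the scatter). Compound 4 `O=C1/C(=C/c2cccnc2)CN(S(=O)(=O)c2ccc(Br)cc2)C/C1=C\c1ccccc1C(F)(F)F` has not yet been measured. It differs from compound 3 in one group on an aromatic carbon, para to a large group, with bromo in place of nitro on an aromatic carbon.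

For the measured compounds named here, no measured step makes this exact swap. The closest guide is the replacement of methyl by nitro at that place, a modest step: a 2.4-fold higher number from compound 2 to compound 3 (0.38 log units; beyond the scatter). Compound 1 also carries the (4-bromophenyl)sulfonyl group and gives 9100 nM, but it differs from compound 4 elsewhere, so it is only a rough guide. Removing the nitro group is therefore expected to give a modest move toward a lower number in this assay, close to the scatter. The expected step is a 1.9-fold lower number from compound 3 to compound 4 (0.27 log units; within the scatter). Compound 4 is estimated at 8500 nM, with an expected range of 4000 nM to 17000 nM.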

Compound 4, half-maximal inhibitory concentration: 5760 nM
Beside the measured number, compound 4's estimate is 1.5-fold (0.17 log units) above it; the range from low to high includes it.
By their numbers in this assay, from the lowest: compounds 4, 2, 1 and 3 (each within the scatter of the next, the first and the last beyond it).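

In this assay, bromo in place of nitro gives a 2.8-fold lower number from compound 3 to compound 4 (0.44 log units; beyond the scatter), so at this place, para to a large group, nitro now stands apart from bromo as well as from methyl. Bromo and methyl, however, cannot be told apart: bromo in place of methyl gives a 1.2-fold lower number from compound 2 to compound 4 (0.07 log units; within the scatter), which lies within the scatter. Elsewhere in the molecule, trifluoromethyl in place of fluoro on an aromatic carbon gives a 1.6-fold lower number from compound 1 to compound 4 (0.20 log units; within the scatter), also within the scatter, so this change shows no clear effect in this assay.

Nothing available explains why nitro differs from the other two groups. Going by these compounds, it remains open whether an amine, a carboxylic acid or a methoxy group at this place would give numbers like those of bromo and methyl or like that of nitro.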